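Swapping a Nitro for Dimethylamino on a Second Core

A few compounds are considered here, and "the series" means these few. Any claim that something is new, unique, unknown or untested is made for them only; others in the source may bear on it.

Of the compounds shown here, three have been measured in an assay on THP-1 cells for antagonist activity at P2X purinoceptor 7 (Homo sapiens), read by ELISA, with a stated time of 30 min; a higher number here means a weaker inhibitor, a lower number a stronger inhibitor. Compound 1 `O=C(c1ccc([N+](=O)[O-])cc1)N1CCC(n2cncc2-c2ccc(OS(=O)(=O)c3cccc4cnccc34)cc2)CC1` gives 8.29 nM. Compound 2 `CN(C)c1ccc(C(=O)N2CCC(n3cncc3-c3ccc(OS(=O)(=O)c4cccc5cnccc45)cc3)CC2)cc1` carries the change dimethylamino in place of nitro on an aromatic carbon on the same core, and in this assay compound 2 gives 2.19 nM. That single exchange produced a 3.8-fold lower number from compound 1 to compound 2 (0.58 log units; beyond the scatter). Compound 3 `O=C(c1ccc([N+](=O)[O-])cc1)N1CCC(c2nc3cc(OS(=O)(=O)c4cccc5cnccc45)ccc3[nH]2)CC1` is built on a different core; the difference between the two cores is not broken down here. In this assay compound 3 gives 17 nM, the highest number of the three, and it stands beyond the scatter from both compound 1 and compound 2.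

Compound 4 `CN(C)c1ccc(C(=O)N2CCC(c3nc4cc(OS(=O)(=O)c5cccc6cnccc56)ccc4[nH]3)CC2)cc1` has not yet been measured. It differs from compound 3 by dimethylamino in place of nitro on an aromatic carbon, and the place of this change is described in the same words as for compound 1 and compound 2, so it is the same change carried onto the second core. Only one earlier instance of this change exists among these compounds, so the expectation rests on a single step. Compound 4 is expected to reach 5 nM, with a range from 2 nM to 14 nM. That estimate means a step of a 3.4-fold lower number from compound 3 to compound 4 (0.53 log units; beyond the scatter), chosen close to the earlier step because compound 1 to compound 2 showed a 3.8-fold lower number from compound 1 to compound 2 (0.58 log units; beyond the scatter), while allowing that the second core may not repeat it exactly.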

Compound 4, half-maximal inhibitory concentration: 121 nM
The estimate for compound 4 lay 24-fold (1.38 log units) below the measured number; measured number outside the range, above it.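

Carried onto the second core, dimethylamino in place of nitro gave a 7.1-fold higher number from compound 3 to compound 4 (0.85 log units; beyond the scatter) in this assay, so an exchange that strengthened inhibition on the core of compound 1 weakened it on the core of compound 3. The two steps point in opposite directions, which shows that in this series the result of this exchange on one core does not predict its result on the other: the same change on two cores in this assay, a 3.8-fold lower number (0.58 log units; beyond the scatter) from compound 1 to compound 2 and a 7.1-fold higher number (0.85 log units; beyond the scatter) from compound 3 to compound 4, 27-fold (1.43 log units) apart, beyond the scatter of two such steps. For the compounds shown here, this comparison does not show which part of the cores makes the difference or why the direction reverses, and with only two pairs of compounds, it cannot say which of the two steps would be the more typical on any further core.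

The compounds shown leave open whether the reversal is specific to dimethylamino or would also appear with another group in the same place, such as an unsubstituted amino group, a methoxy group or a carboxylic acid. Such a group, placed para to the large group on both cores, would show whether the two cores keep responding in opposite ways or whether this pair of steps is a special case.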